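Returning to an amide at the carbonyl of compound 3

The source may hold more compounds than are shown below. What is called first, only, known or untested is meant among the compounds shown, and "the series" means these compounds.

Measured so far:
- compound 1, `CCn1c(C(=O)NCCN(C)C)ccc1C(CC)(CC)c1ccc(OCC(O)C(C)(C)C)c(C)c1`: 14 nM
- compound 2, `CCn1c(C(=O)NCCCN(C)C)ccc1C(CC)(CC)c1ccc(OCC(O)C(C)(C)C)c(C)c1`: 37 nM
- compound 3, `C#CCCOC(=O)c1ccc(C(CC)(CC)c2ccc(OCC(O)C(C)(C)C)c(C)c2)n1CC`: 1030 nM

These three share one core and differ only in the group attached to the carbonyl carbon. In an assay on HL-60 cells for agonist activity at vitamin D3 receptor (Homo sapiens), read by microscopy, with a stated time of 96 h (on this read-out lower numbers stand for an effect already at smaller amounts and higher numbers for an effect only at larger amounts of compound), compound 3 has the highest number of the three; its nearest neighbour is compound 2 and the step between them is a 28-fold higher number from compound 2 to compound 3 (1.44 log units; beyond the scatter), while the step from the lowest number is a 74-fold higher number from compound 1 to compound 3 (1.87 log units; beyond the scatter). Compound 4, `CC[C@@H](C)[C@H](NC(=O)c1ccc(C(CC)(CC)c2ccc(OCC(O)C(C)(C)C)c(C)c2)n1CC)C(=O)O`, has not yet been measured. Compared with compound 3 it carries (1-carboxy-2-methylbutyl)amino in place of (but-3-yn-1-yl)oxy on a carbonyl carbon.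

Among the compounds with values here, two measured steps bear on this change, since both replace an amino-type group on the carbonyl carbon with the (but-3-yn-1-yl)oxy group: a 74-fold higher number from compound 1 to compound 3 (1.87 log units; beyond the scatter) and a 28-fold higher number from compound 2 to compound 3 (1.44 log units; beyond the scatter), both large and in the same direction. Compound 4 reverses that kind of exchange, so a large drop in number is expected in this assay. Within the data shown here, the chain entering in compound 4 is, however, not one of the two that were measured, and no other compound shows what such a chain does here; the expectation therefore carries a wide range. For compound 4 the estimated value is 150 nM, between 30 nM and 800 nM, which is an expected step of a 6.9-fold lower number from compound 3 to compound 4 (0.84 log units; beyond the scatter).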

Compound 4, half-maximal effective concentration: 2.3 nM
Beside the measured number, compound 4's estimate is 65-fold (1.81 log units) above it, and the stated range ends above it.
By their numbers in this assay, from the lowest: compound 4; then compound 1; then compound 2; then compound 3.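

In this assay, the effect of putting an amide back at this carbonyl carbon is far larger with the (1-carboxy-2-methylbutyl)amino group, with a 450-fold lower number from compound 3 to compound 4 (2.65 log units; beyond the scatter), than the two earlier steps between compound 3 and the amides with a dimethylamino chain suggested. Those earlier amides could have implied that the dimethylamino end of the chain was needed for a low number, but compound 4 has no such amine and instead carries a carboxylic acid, giving a 16-fold lower number from compound 2 to compound 4 (1.21 log units; beyond the scatter) and a 6.1-fold lower number from compound 1 to compound 4 (0.78 log units; beyond the scatter). With every one of these steps beyond the scatter, compound 4 has the lowest number of the four, which shows that this position accepts a branched chain ending in a carboxylic acid and does not depend on a dimethylamino group.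

Compound 4 brings in the carboxylic acid, the branched carbon chain and the two defined stereocentres together, so the compounds shown leave open which of these matters, a question that a methyl ester in place of the acid, an unbranched chain ending in a carboxylic acid, or the opposite stereocentres could address. No measurement given here accounts for the size of this result.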